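Fluoro in Place of Methyl on an Aromatic Carbon

The compounds below may be only part of what the source reports. "The series", "measured", "known", "first", "only" and "open" are said of these compounds alone.

Going by the values given here, in a functional assay on HL-60 cells (Homo sapiens) for cytotoxicity, read by WST assay, with a stated time of 48 h (a higher number here means that more compound is needed for the effect, a lower number that less compound is needed), compound 2 `Cc1cccc(C[C@H]2C(=O)OC[C@@H]2Cc2ccccc2)c1` gives 53000 nM, the higher of the two numbers so far, while compound 1 `CCCCOc1cccc(C[C@H]2C(=O)OC[C@@H]2Cc2ccccc2)c1` gives 26000 nM. Compound 3 `O=C1OC[C@H](Cc2ccccc2)[C@H]1Cc1cccc(F)c1` has fluoro in place of methyl on an aromatic carbon, meta to a large group: fluoro in place of methyl on an aromatic carbon. Among the compounds with values here, the only measured step at that carbon, a 2.0-fold higher number from compound 1 to compound 2 (0.31 log units; beyond the scatter), was modest and put methyl in place of butoxy. With nothing larger to go on, no step beyond the scatter is expected in this assay. For compound 3 the estimated value is 48000 nM, within an expected range of 22000 nM to 100000 nM. This estimate means an expected 1.1-fold lower number from compound 2 to compound 3 (0.04 log units; within the scatter).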

Compound 3, half-maximal effective concentration: 75000 nM
Beside the measured number, compound 3's estimate is 1.6-fold (0.19 log units) below it; low and high end bracket the measured number.
By their numbers in this assay, from the lowest: compound 1; then compounds 2 and 3 (each within the scatter of the next).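

In this assay, fluoro and methyl on this aromatic carbon cannot be told apart (a 1.4-fold higher number from compound 2 to compound 3 (0.15 log units; within the scatter)), so going from 3-methylphenyl to 3-fluorophenyl makes no clear difference. Butoxy now stands apart from two small groups rather than one (a 2.9-fold higher number from compound 1 to compound 3 (0.46 log units; beyond the scatter)), though this step is only modest. Open, on these data alone, is whether an amine, a carboxylic acid or a chain longer than butoxy on this carbon would shift the number further, and whether a methoxy group would already match butoxy. No measurement shown here accounts for these numbers.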